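Benzyloxy in Place of Trifluoromethyl: Expectation for Compound 3

This account rests on a few compounds, and the source may have more. Where it says the series, first, only, none or still open, it means among the compounds named here.

The series keeps one shared core and varies a single substituent on an aromatic carbon. Compound 1 `CN1CCCN(CCn2ccc3ccc(F)cc32)CC1` carries fluoro there, and in an assay on HEK293 cells for binding affinity to 5-hydroxytryptamine receptor 7 (Homo sapiens), read by radioligand binding (on this read-out lower numbers stand for stronger inhibition and higher numbers for weaker inhibition), compound 1 gives 288 nM. Going by the values given here, compound 2 `CN1CCCN(CCn2ccc3ccc(C(F)(F)F)cc32)CC1` carries trifluoromethyl, and in this assay compound 2 gives 23 nM, the lowest of the two numbers so far; the only measured step, a 13-fold lower number from compound 1 to compound 2 (1.10 log units; beyond the scatter), is large. Compound 3 `CN1CCCN(CCn2ccc3ccc(OCc4ccccc4)cc32)CC1` is not yet measured in this assay. The change is benzyloxy in place of trifluoromethyl on an aromatic carbon. Among the compounds with values here, no measured step bears on this exchange directly: the single known step compares fluoro with trifluoromethyl at the same place and says nothing about benzyloxy, so it gives no guide to direction. A shift of no more than the scatter in either direction is the working expectation, with a 1.7-fold higher number from compound 2 to compound 3 (0.24 log units; within the scatter) as the estimated step. Compound 3 is accordingly estimated at 40 nM in this assay, with a range from 8 nM to 200 nM.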

Compound 3, inhibition constant: 182 nM
The estimate for compound 3 lay 4.6-fold (0.66 log units) below the measured number; the range from low to high includes it.
By their numbers in this assay, from the lowest: compound 2; then compounds 3 and 1 (each within the scatter of the next).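

In this assay the exchange of trifluoromethyl for benzyloxy gives a 7.9-fold higher number from compound 2 to compound 3 (0.90 log units; beyond the scatter) and so does not keep the low number of compound 2 at this aromatic carbon. Benzyloxy and fluoro are not separated here, with a 1.6-fold lower number from compound 1 to compound 3 (0.20 log units; within the scatter) despite the added six-membered aromatic ring of carbon only and the hydrogen-bond acceptor that benzyloxy brings, so among these three groups only trifluoromethyl stands apart at this position. No evidence on hand accounts for either step.

The compounds shown leave open whether the oxygen or the added ring of benzyloxy governs the step from trifluoromethyl. They also leave open how methoxy, an amine or a carboxylic acid on the same aromatic carbon would stand against compound 2.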